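The source may hold more compounds than are shown below. What is called first, only, known or untested is meant among the compounds shown, and "the series" means these compounds.

Of the compounds shown here, three sharing one core have been tested in an ADME assay on MT4 cells (Homo sapiens) for cytotoxicity, read by MTT assay, with a stated time of 4 days; a higher number here means that more compound is tolerated, a lower number that less compound is tolerated. Compound 2 `O=C(COc1cccc2ccccc12)N/N=C/c1ccc(Br)cc1` gives 106 ug/mL. Compound 3 `COc1cc(/C=N/NC(=O)COc2cccc3ccccc23)cc(OC)c1O` gives 16.3 ug/mL, and compound 1 `COc1ccc(/C=N/NC(=O)COc2cccc3ccccc23)cc1O` gives 7.05 ug/mL. Among these three numbers compound 2 stands highest, meaning it is the best tolerated of the set: the gap to compound 3 lies beyond the usual scatter, and the gap to compound 1 is wider still.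

Compound 4 `COc1ccc(/C=N/NC(=O)COc2cccc3ccccc23)cc1` has not yet been measured in this assay. It differs from compound 2 at a single point: methoxy in place of bromo on an aromatic carbon. Going by the values given here, no measured pair shows this same change on its own, so its effect cannot be read directly from the data. Both compounds that carry a methoxy group, compound 1 and compound 3, fall beyond the scatter below compound 2, which is the only hint available. On that basis the expectation for compound 4 is a moderate drop, a 2.7-fold lower number from compound 2 to compound 4 (0.42 log units; beyond the scatter), from compound 2. The value expected for compound 4 in this assay is therefore 40 ug/mL, with a range from 12 ug/mL to 120 ug/mL.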

Compound 4, half-maximal cytotoxic concentration: 76.9 ug/mL
Beside the measured number, compound 4's estimate is 1.9-fold (0.28 log units) below it, within the range that was stated.
By their numbers in this assay, from the lowest: compound 1; then compound 3; then compounds 4 and 2 (each within the scatter of the next).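

In this assay the change from 4-bromophenyl to 4-methoxyphenyl, on an aromatic carbon para to a large group, makes no clear difference (a 1.4-fold lower number from compound 2 to compound 4 (0.14 log units; within the scatter)), so bromo and methoxy cannot be told apart at this position. The large step appears instead when the hydroxy of compound 1 gives way to hydrogen (an 11-fold higher number from compound 1 to compound 4 (1.04 log units; beyond the scatter)), which places the low tolerance of compound 1 with that hydroxy rather than with the methoxy the two compounds share. No measurement at hand explains either step.

From the compounds shown here alone, whether an amine or a carboxylic acid at this position would stay level with bromo and methoxy remains open. Also open, going by these compounds, is whether the hydroxy has the same large effect on a ring without the methoxy.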